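The source may report more compounds than this note shows. Statements on the series, on what has been measured and on what is new or still open speak of the compounds shown alone.

Of the compounds shown here, three sharing one core have been measured in a physicochemical assay for solubility, with a stated time of 18 h, at pH 7.4; on this read-out lower numbers stand for lower solubility and higher numbers for higher solubility. Compound 1 `FC(F)(F)c1ccc(-c2ccc3c(NCCCNCc4ccco4)ccnc3c2)cc1` gives 32000 nM, compound 2 `COc1ccccc1Oc1ccc2c(NCCCNCc3ccco3)ccnc2c1` gives 14500 nM, and compound 3 `COc1ccc(-c2ccc3c(NCCCNCc4ccco4)ccnc3c2)cc1` gives 32000 nM. Compound 3 is therefore level with compound 1, and together they hold the highest number of the three. Compound 4 `N#Cc1ccc(Cc2ccc3c(NCCCNCc4ccco4)ccnc3c2)cc1` has not yet been measured. It differs from compound 3 in one place, with 4-cyanobenzyl in place of 4-methoxyphenyl on an aromatic carbon.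

Three measured steps at this same place offer a guide. Exchanging only trifluoromethyl for methoxy gave no change at the digits printed from compound 1 to compound 3 (within the scatter). Exchanging the whole group had a modest effect, with a 2.2-fold lower number from compound 1 to compound 2 (0.34 log units; beyond the scatter) and a 2.2-fold higher number from compound 2 to compound 3 (0.34 log units; beyond the scatter). The second of these whole-group steps is the most useful, since in compound 2, as in compound 4, the outer ring is not joined straight to the core. For the measured compounds named here, compound 2 has the lowest number so far at 14500 nM, so a small move down in this assay seems more likely than a move up. The estimated step, a 1.4-fold lower number from compound 3 to compound 4 (0.14 log units; within the scatter), is expected to stay within the scatter. For compound 4 the expected value is 23000 nM, with an estimated range from 11000 nM to 40000 nM.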

Compound 4, solubility: 4200 nM
For compound 4 the middle estimate is 5.5-fold (0.74 log units) above the measured one, outside the stated range (below it).
By their numbers in this assay, from the lowest: compound 4; then compound 2; then compounds 1 and 3 (each within the scatter of the next).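

In this assay, for the compounds shown here, this position turns out to be far more sensitive than the earlier compounds suggested: a 7.6-fold lower number from compound 3 to compound 4 (0.88 log units; beyond the scatter) and a 7.6-fold lower number from compound 1 to compound 4 (0.88 log units; beyond the scatter), while the largest earlier exchange here was only a 2.2-fold higher number from compound 2 to compound 3 (0.34 log units; beyond the scatter). An outer ring that is not joined straight to the core does not by itself set the level, since the two such groups also differ clearly: a 3.5-fold lower number from compound 2 to compound 4 (0.54 log units; beyond the scatter). The new change alters the link to the core and the group on the outer ring together, and no measurement available here gives a reason for the drop.

The compounds shown leave open whether the benzyl link, the nitrile or the two in combination accounts for the lower number, and 4-cyanophenyl and 4-methoxybenzyl at this place would each change only one of these features relative to compound 3. Going by these compounds, it also remains open how this assay would respond to a group with no outer aromatic ring at this position, such as an amine or a carboxylic acid.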